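A few compounds are considered here, and "the series" means these few. Any claim that something is new, unique, unknown or untested is made for them only; others in the source may bear on it.

Working notes on the series.

Compound 1 `COc1ccc(OCCCCCN2CCCC(COC(=O)c3ccccc3N3C(=O)CC(C)C3=O)C2)cc1` is the starting point here. For the measured compounds named here, in an in vitro functional assay on HEK ts201 cells for antagonist activity at Neuronal acetylcholine receptor; alpha4/beta2 (Homo sapiens), read by fluorescence and calcium flux (a higher number here means a weaker inhibitor, a lower number a stronger inhibitor), compound 1 gives 14500 nM, the only number recorded for it, alongside one further entry that carries no single value. Compound 2 `O=C(OCC1CCN(CCCc2ccccc2)CC1)c1ccccc1-c1ccccc1` differs from compound 1 in several places at once, so no single step can be read between them; in this assay compound 2 gives 8130 nM; 8100 nM (2 entries), and the repeated entries the several entries of compound 2 in this assay, 8130 nM; 8100 nM (2 entries) sit close together.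

Compound 3 `CC1CC(=O)N(c2ccccc2C(=O)OCC2CCCN(CCCC3CCCCC3)C2)C1=O` is not yet measured in this assay. It differs from compound 1 in one place: cyclohexyl in place of 2-(4-methoxyphenoxy)ethyl on a saturated chain carbon, three bonds along the chain from an amine nitrogen in a ring. Going by the values given here, no measured step touches this part of the molecule, so the size of the change is open. The expectation is a small shift at most, in either direction, not clearly beyond the scatter, so that the step of a 1.5-fold lower number from compound 1 to compound 3 (0.16 log units; within the scatter) is estimated as modest. For compound 3 the expected value in this assay is 10000 nM, with a range from 3000 nM to 40000 nM.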

Compound 3, half-maximal inhibitory concentration: 14500 nM
Compound 3: middle estimate off by 1.5-fold (0.16 log units), on the low side; measured number inside the range.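

For the compounds shown here, this is the first step read at this position: cyclohexyl in place of 2-(4-methoxyphenoxy)ethyl gives no change at the digits printed from compound 1 to compound 3 (within the scatter) in this assay. For this pair, then, the aromatic ring and both oxygens of the leaving group can go, and the chain can end in a non-aromatic carbon ring, with no readable shift in the number. The flat step can be taken at face value, since repeat entries in the series sit close together: the several entries of compound 2 in this assay, 8130 nM; 8100 nM (2 entries)

One pair cannot show whether this position is insensitive in general or whether these two groups merely happen to match. As far as these compounds go, a basic amine or a carboxylic acid at the end of the chain would test that, and the same swap on the core of compound 1 with a shorter chain remains open.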